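Terminal aryl swap at the biaryl end of the series

The compounds below may be only part of what the source reports. "The series", "measured", "known", "first", "only" and "open" are said of these compounds alone.

Measured so far:
Compound 1, `CC[C@@H](Nc1c(C#N)c(-c2ccc(-c3cccc(C)c3)cc2)nc2cnccc12)C(N)=O`: in a physicochemical assay for lipophilicity, read by HPLC, at pH 7.5 (on this read-out lower numbers stand for lower lipophilicity and higher numbers for higher lipophilicity), compound 1 gives 3.
Compound 2, `CC[C@@H](Nc1c(C#N)c(-c2ccc(-c3ccc(Cl)cc3)cc2)nc2cnccc12)C(N)=O`: in this assay compound 2 gives 3.1.

Within the data shown here, compound 2 and compound 1 lie within the usual scatter of each other in this assay, the only recorded step being a number 0.10 log units higher from compound 1 to compound 2 (within the scatter). Among the measured compounds shown here, that step exchanges one terminal aryl ring for another and is the sole measured comparison.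

The unmeasured compound 3, `CC[C@@H](Nc1c(C#N)c(-c2ccc(-c3ccccc3F)cc2)nc2cnccc12)C(N)=O`, differs from compound 2 by 2-fluorophenyl in place of 4-chlorophenyl on an aromatic carbon. For the measured compounds named here, no measured step involves a 2-fluorophenyl group, so the single step from compound 1 to compound 2 bears on the new change only in that a terminal aryl swap of this kind produced no movement beyond the scatter. With a chlorine leaving and a fluorine entering on the terminal ring, a downward step in this assay is nevertheless expected for compound 3, of the size a number 0.60 log units lower from compound 2 to compound 3 (beyond the scatter), somewhat beyond the scatter. The estimate for compound 3 in this assay is 2.5, with a range of 2.2 to 2.8.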

Compound 3, distribution coefficient: 2.7
Estimate against measurement, compound 3: 0.20 log units below; the range from low to high includes it.
By their numbers in this assay, from the lowest: compounds 3, 1 and 2 (each within the scatter of the next, the first and the last beyond it).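

In this assay, the terminal aryl position now shows its first step beyond the scatter, a number 0.40 log units lower from compound 2 to compound 3 (beyond the scatter), although the group leaving and the group entering match in heavy-atom count, with no hydrogen-bond donors or acceptors and no net charge on either. Among these compounds, the same 2-fluorophenyl group in place of 3-methylphenyl gives a number 0.30 log units lower from compound 1 to compound 3 (within the scatter), so the swap at this aromatic carbon, para to a large group, does not give a step beyond the scatter against both earlier groups; only the pair of compound 2 and compound 3 separates that far, and its size remains modest. Nothing available accounts for this step or shows why it differs from the step against compound 1.

The change from 4-chlorophenyl to 2-fluorophenyl alters both the halogen and its place on the ring, and these three compounds cannot separate the two. Also open is how far this read-out would move with a terminal ring bearing an amine or a carboxylic acid, since all three groups shown carry only a methyl or a halogen on the ring.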